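The source may report more compounds than this note shows. Statements on the series, on what has been measured and on what is new or still open speak of the compounds shown alone.

Measured so far:
- compound 1, `COc1cc(/C=C/C(=O)c2cccc(-n3cc(-c4ccccc4)[nH]c3=O)c2)ccc1O`: 3310 nM
- compound 2, `O=C(/C=C/c1cccc(O)c1)c1cccc(-n2cc(-c3ccccc3)[nH]c2=O)c1`: 3140 nM

Within the data shown here, in a functional assay on SN12C cells (Homo sapiens) for inhibition (a higher number here means a weaker inhibitor of growth, a lower number a stronger inhibitor of growth), compound 2 and compound 1 stand within the scatter of each other; the only measured step, a 1.1-fold lower number from compound 1 to compound 2 (0.02 log units; within the scatter), exchanges the aryl on the double-bonded chain and leaves the number essentially unchanged. Among the measured compounds shown here, compound 2 therefore stands level with its single neighbour, with no separation beyond the scatter.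

Compound 3, `O=C(/C=C/c1cccc(O)c1)c1cccc(-n2cc(-c3ccc(Cl)cc3)[nH]c2=O)c1`, differs from compound 2 by chloro in place of hydrogen on an aromatic carbon. For the measured compounds named here, no measured step touches this part of the structure: the one step known concerns the hydroxyphenyl end of the chain, not the phenyl on the core, so it gives no direction for the present change. Absent any comparable step, the working expectation for compound 3 is a number close to that of compound 2, a 1.0-fold lower number from compound 2 to compound 3 (0.02 log units; within the scatter), within the scatter. The estimate for compound 3 in this assay is 3000 nM, with a range from 1500 nM to 6000 nM.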

Compound 3, concentration for 50% growth inhibition: 1950 nM
The estimate for compound 3 lay 1.5-fold (0.19 log units) above the measured number, and the stated range covers the measured number.
By their numbers in this assay, from the lowest: compounds 3, 2 and 1 (each within the scatter of the next).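

In this assay, among these compounds, the step of a 1.6-fold lower number from compound 2 to compound 3 (0.21 log units; within the scatter) is the first measured change on the phenyl attached to the shared core, here phenyl to 4-chlorophenyl. A single chlorine on this aromatic carbon, para to a large group, is accepted without a separation beyond the scatter, so this position, like the aryl on the double-bonded chain, has so far produced no clear difference in growth inhibition. No measurement is available that bears on this result.

The compounds shown leave open whether a larger group at this position, such as methoxy, trifluoromethyl, an amine or a carboxylic acid, would move the number beyond the scatter. They also leave open whether 4-chlorophenyl would give a similar step when paired with the 4-hydroxy-3-methoxyphenyl of compound 1 on the chain.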